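From Methyl to Pyridinylmethoxy: Forecasting Compound 4

The source may report more compounds than this note shows. Statements on the series, on what has been measured and on what is new or still open speak of the compounds shown alone.

Of the compounds shown here, three sharing one core have been measured in an ADME assay on HEK293 cells for agonist activity at Toll-like receptor 8 (Homo sapiens), read by a luciferase reporter, with a stated time of 6 h; a higher number here means that more compound is needed for the effect, a lower number that less compound is needed. Compound 1 `CCCCNc1nc(N)nc2c(F)cccc12` gives 0.3 uM. Compound 2 `CCCCNc1nc(N)nc2cc(C(=O)N(C)C)ccc12` gives 0.5 uM. Compound 3 `CCCCNc1nc(N)nc2cccc(C)c12` gives 0.3 uM, level with compound 1 at the digits shown, the two together the lowest of the three numbers, while compound 2 differs from compound 3 only by an amount within the scatter. Compound 4 `CCCCNc1nc(N)nc2cccc(OCc3ccccn3)c12` has not yet been measured. It differs from compound 3 in one place: (pyridin-2-yl)methoxy in place of methyl on an aromatic carbon. Among the compounds with values here, no pair of measured compounds differs in just one place, so no measured step guides this change. A modest rise in this assay is expected, though a step no larger than the scatter is also plausible. Compound 4 is therefore estimated at 0.6 uM, with a range from 0.15 uM to 3 uM. That estimate corresponds to an expected step of a 2.0-fold higher number from compound 3 to compound 4 (0.30 log units; within the scatter).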

Compound 4, minimum effective concentration: 18.5 uM
Compound 4: the middle estimate sits 31-fold (1.49 log units) below what was measured; the measured number lies above the stated range.
By their numbers in this assay, from the lowest: compounds 1, 3 and 2 (each within the scatter of the next); then compound 4.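

In this assay, replacing methyl with (pyridin-2-yl)methoxy on this aromatic carbon gives a 62-fold higher number from compound 3 to compound 4 (1.79 log units; beyond the scatter). Within the data shown here, this is the first step beyond the scatter, and it shows that this position does not tolerate every group equally, which the closely grouped earlier compounds could not reveal. No measurement here explains the rise. Still open, as far as these compounds go, is which part of the new group matters: the oxygen link, the added length or the pyridine ring. Methoxy or benzyloxy at this position would help separate these parts.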